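From dimethylamino to methoxy on an aromatic carbon

The source may report more compounds than this note shows. Statements on the series, on what has been measured and on what is new or still open speak of the compounds shown alone.

- Compound 1 `CN(Cc1ccc(Cl)cc1)Cc1ccccc1CNc1ccnc2cc(Cl)ccc12`: 7.44
- Compound 2 `CN(Cc1ccc(N(C)C)cc1)Cc1ccccc1CNc1ccnc2cc(Cl)ccc12`: 7.4

Both compounds were measured in a physicochemical assay for acid dissociation. Among the compounds with values here, only two numbers exist so far, and compound 2, at 7.4, lies within the scatter of compound 1, at 7.44.

The next structure, compound 3 `COc1ccc(CN(C)Cc2ccccc2CNc2ccnc3cc(Cl)ccc23)cc1`, keeps the shared core and differs from compound 2 in a single group: methoxy in place of dimethylamino on an aromatic carbon. Methoxy stands in place of dimethylamino on an aromatic carbon, para to a large group.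

Within the data shown here, one measured step bears on this change. It is a number 0.04 log units lower from compound 1 to compound 2 (within the scatter), and it came with dimethylamino in place of chloro at that same spot. Among the measured compounds shown here, a single step establishes no rule, and no methoxy compound has been measured yet. Even so, that small step gives no reason to expect a shift beyond the scatter in this assay.

The expected step is no change at the digits printed from compound 2 to compound 3 (within the scatter). Compound 3 is estimated at 7.4, with an expected range from 7.1 to 7.7.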

Compound 3, acid dissociation constant: 7.47
Compound 3: middle estimate off by 0.07 log units, on the low side; the range from low to high includes it.
By their numbers in this assay, from the lowest: compounds 2, 1 and 3 (each within the scatter of the next).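

In this assay, methoxy in place of dimethylamino on the aromatic carbon gives a number 0.07 log units higher from compound 2 to compound 3 (within the scatter) and methoxy in place of chloro gives a number 0.03 log units higher from compound 1 to compound 3 (within the scatter) at the same place. Where the earlier compounds offered a single pair, three different groups at this place, para to a large group, now lie within the scatter of one another, so among compounds 1, 2 and 3 the choice of group leaves no readable mark on this number. Nothing measured here speaks to why these three values sit so close together.

From the compounds shown here alone, what remains open is whether a group of another kind at this place, such as a carboxylic acid or a longer carbon chain, would carry the number beyond the scatter. The compounds shown also cannot tell what a change elsewhere on the shared core would do to this reading.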